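The compounds below may be only part of what the source reports. "The series", "measured", "known", "first", "only" and "open" are said of these compounds alone.

The account follows a single change made to compound 1 `CNC(=O)c1cc(C(=O)N[C@H]2[C@@H]3COC[C@@H]32)cc2c1OC[C@H]2c1ccccn1`, whose solubility is read in a physicochemical assay for solubility; a lower number here means a less soluble compound, a higher number a more soluble compound. For compound 1 the result is a limit of the assay rather than a number: it gives >= 158 ug/mL. Two further compounds from the same study stand in the same position. Compound 2 `CNC(=O)c1cc(C(=O)NC)c2c(c1)[C@H](c1ccccc1)[C@@H](CF)O2` also reaches a limit, giving >= 149 ug/mL. Compound 3 `CCC(=O)N1C[C@@H]2[C@H](C1)[C@H]2NC(=O)c1cc(C(=O)NC)c2c(c1)[C@H](c1ccccc1)CO2` likewise reaches a limit, with >= 163 ug/mL. For the measured compounds named here, none of the three yields a number, so no step between measured compounds can be drawn from them; each simply sits at its own limit, (the limit of >= 149 ug/mL in this assay, at which 1 of the 3 values shown sits), the limit of >= 158 ug/mL in this assay, at which 1 of the 3 values shown sits, and (the limit of >= 163 ug/mL in this assay, at which 1 of the 3 values shown sits).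

Compound 4 `CNC(=O)c1cc(C(=O)N[C@H]2[C@@H]3COC[C@@H]32)cc2c1OC[C@H]2c1ccncc1` has not been measured in this assay. It differs from compound 1 in one place: pyridin-4-yl in place of pyridin-2-yl on a saturated ring carbon. The two compounds have the same atoms, joined differently. Compound 1 stands at a limit with >= 158 ug/mL. The expected step is small, within the scatter and of no fixed direction, the estimate being a step that the limit leaves unreadable from compound 1 to compound 4. Compound 4 is expected to give 160 ug/mL, within a range from 70 ug/mL to 250 ug/mL, and is most likely to be reported once more as a limit.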

Compound 4, solubility: >= 184 ug/mL
Compound 4 was reported as a limit; the forecaster's own chance of this, stated with the estimate: 70%; at least 1.1-fold (0.06 log units) between middle value and limit.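

In this assay, compound 1 and compound 4 both stand at limits of the assay rather than at numbers, so no step can be read between them for pyridin-4-yl in place of pyridin-2-yl. The compounds shown leave open where the true values of compound 1 and compound 4 lie in this assay, and whether this change moves the read-out at all.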